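The source may report more compounds than this note shows. Statements on the series, on what has been measured and on what is new or still open speak of the compounds shown alone.

Compound 1 `COc1cc(/C=C2/S/C(=N/c3ccccc3)N(Cc3ccncc3)C2=O)ccc1O` gives 28000 nM
Compound 2 `COc1ccc(OC)c(/C=C2/S/C(=N/c3ccccc3)N(Cc3ccncc3)C2=O)c1` gives 37000 nM
Compound 3 `O=C1/C(=C\c2cccc(O)c2)S/C(=N/c2ccccc2)N1Cc1ccncc1` gives 43600 nM

These values come from a functional assay on MCF7 cells (Homo sapiens) for cytotoxicity, read by MTT assay, with a stated time of 48 h (a lower number here means a stronger inhibitor, a higher number a weaker inhibitor), and lie within the scatter of one another, so compound 3 stands level with the other two. Next is compound 4 `O=C1/C(=C\c2ccccn2)S/C(=N/c2ccccc2)N1Cc1ccncc1` with pyridin-2-yl in place of 3-hydroxyphenyl on a double-bonded chain carbon bound to a double-bonded ring carbon. Three measured steps at that same place bear on it (a 1.6-fold higher number from compound 1 to compound 3 (0.19 log units; within the scatter); a 1.2-fold higher number from compound 2 to compound 3 (0.07 log units; within the scatter); a 1.3-fold higher number from compound 1 to compound 2 (0.12 log units; within the scatter)), and all lie within the scatter. None of them brings in a pyridin-2-yl group, so the basis is thin. The expected step in this assay is a 1.1-fold lower number from compound 3 to compound 4 (0.04 log units; within the scatter) and amounts to none beyond the scatter, with no firm direction. Compound 4 is expected at 40000 nM (estimated range 18000 nM to 90000 nM).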

Compound 4, half-maximal inhibitory concentration: 21100 nM
Compound 4: the middle estimate sits 1.9-fold (0.28 log units) above what was measured; the measured number falls inside the stated range.
By their numbers in this assay, from the lowest: compounds 4, 1, 2 and 3 (each within the scatter of the next, the first and the last beyond it).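

Within the data shown here, at the place on a double-bonded chain carbon bound to a double-bonded ring carbon, pyridin-2-yl gives the first step beyond the scatter in this assay: a 2.1-fold lower number from compound 3 to compound 4 (0.32 log units; beyond the scatter). That step is modest and holds only against 3-hydroxyphenyl, since the other two comparisons, a 1.8-fold lower number from compound 2 to compound 4 (0.24 log units; within the scatter) and a 1.3-fold lower number from compound 1 to compound 4 (0.12 log units; within the scatter), stay within the scatter. No measurement available here accounts for the step.

Still open, on these data alone, is how an aminophenyl or a carboxyphenyl group would read at this place. Also open, as far as these compounds go, is whether the step from 3-hydroxyphenyl to pyridin-2-yl persists with a different group on the shared core.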